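A few compounds are considered here, and "the series" means these few. Any claim that something is new, unique, unknown or untested is made for them only; others in the source may bear on it.

Measured compounds:
compound 1, `C/C(=N/O)c1ccc(NC(=O)Cn2nc(-c3ccccc3)nc2N)cc1`: 34%
compound 2, `c1ccc(-c2nc3sc(-c4ccccc4)cn3n2)cc1`: 13%
compound 3, `C/C(=N/O)c1ccc(NC(=O)Cn2nc(C(F)(F)F)nc2N)cc1`: 25.6%

Of the compounds shown here, three have been tested in a functional assay on UACC-257 cells (Homo sapiens) for inhibition, read by sulforhodamine B assay, with a stated time of 48 h, tested at 10 uM; on this read-out lower numbers stand for less inhibition of growth and higher numbers for more inhibition of growth at the one concentration tested. Compound 2 has the lowest of the three numbers; the nearest to it is compound 3, which lies beyond the scatter above it, and the furthest is compound 1, also beyond the scatter above it. Within the data shown here, compounds 1 and 3 share one core, and their step of a number 8.4 percentage points lower from compound 1 to compound 3 (within the scatter) is the only measured step; compound 2 has a core of its own, unrelated to theirs.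

The next compound, compound 4, `Clc1ccc(-c2cn3nc(-c4ccccc4)nc3s2)cc1`, is made from compound 2 by one change: chloro in place of hydrogen on an aromatic carbon. Cut one bond further out, the difference reads phenyl to 4-chlorophenyl, sitting on an aromatic carbon of a six-membered aromatic ring of carbon only.

Among the measured compounds shown here, no measured step bears directly on this change. For the measured compounds named here, the one step on record, from compound 1 to compound 3, swaps trifluoromethyl for phenyl on a different core and stays within the scatter, so it gives no guide for a chloro entering a phenyl ring. The writer therefore expects no step beyond the scatter, with the value of compound 4 estimated near that of compound 2: a number 3 percentage points higher from compound 2 to compound 4 (within the scatter). Compound 4 is expected to give about 16% in this assay, with a likely range from 3% to 32%.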

Compound 4, percent growth inhibition at one concentration: 15%
Compound 4: middle estimate off by 1 percentage points, on the high side, within the range that was stated.
By their numbers in this assay, from the lowest: compounds 2 and 4 (each within the scatter of the next); then compounds 3 and 1 (each within the scatter of the next).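

In this assay, among these compounds, the core of compound 2 now has a measured step of its own, a number 2 percentage points higher from compound 2 to compound 4 (within the scatter), where the earlier compounds offered a single step on the unrelated core of compound 1. At this position, on an aromatic carbon of a six-membered aromatic ring of carbon only and para to a large group, chloro in place of hydrogen therefore leaves the two compounds indistinguishable on this read-out, so this one substitution gives no sign that the position responds to change. Nothing at hand explains why the step is this small, and no supporting measurement bears on the result.

What the compounds shown leave open is whether a different group at the same place, such as an amine, a carboxylic acid or a methoxy group, would give a step beyond the scatter. They also leave open whether chloro would behave in the same way on the other phenyl ring of compound 2, since a single substitution on this core says nothing about the rest of it.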